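Moving one fluorine on the phenyl group

A few compounds are considered here, and "the series" means these few. Any claim that something is new, unique, unknown or untested is made for them only; others in the source may bear on it.

- compound 1 `Cc1nc(-c2cccc(F)c2)c(C(=O)N2CCN(c3cccc(Cl)c3)CC2)o1` gives 33.7 nM
- compound 2 `Cc1nc(-c2ccc(F)cc2)c(C(=O)N2CCN(c3cc(Cl)cc(Cl)c3)CC2)o1` gives 52.1 nM
- compound 3 `COc1cc(OC)cc(N2CCN(C(=O)c3oc(C)nc3-c3ccc(F)cc3)CC2)c1` gives 38.5 nM

In a functional assay on HL-60 cells (Homo sapiens) for inhibition, read by MTT assay, with a stated time of 72 h (on this read-out lower numbers stand for stronger inhibition and higher numbers for weaker inhibition), compound 3 gives 38.5 nM, within the scatter of both other compounds, so the three cannot be ranked. Compound 4 `COc1cc(OC)cc(N2CCN(C(=O)c3oc(C)nc3-c3cccc(F)c3)CC2)c1` has 3-fluorophenyl in place of 4-fluorophenyl on an aromatic carbon. Among the compounds with values here, the one measured step, a 1.4-fold lower number from compound 2 to compound 3 (0.13 log units; within the scatter), concerns a different group and stays within the scatter. Within the data shown here, no measured step tests this fluorine change directly. Compound 1 also carries 3-fluorophenyl, and compound 1 at 33.7 nM lies within the scatter of compound 3. No step beyond the scatter is therefore expected in this assay. The estimated change is a 1.1-fold lower number from compound 3 to compound 4 (0.03 log units; within the scatter). For compound 4 the estimate is 36 nM, with an expected range of 17 nM to 75 nM.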

Compound 4, half-maximal inhibitory concentration: 28.2 nM
Estimate against measurement, compound 4: 1.3-fold (0.11 log units) above, within the range that was stated.
By their numbers in this assay, from the lowest: compounds 4, 1, 3 and 2 (each within the scatter of the next).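

In this assay, the direct test of moving the fluorine, with 3-fluorophenyl in place of 4-fluorophenyl, gives a 1.4-fold lower number from compound 3 to compound 4 (0.14 log units; within the scatter), so either placement fits this position with no readable change. With 3-fluorophenyl kept, 3,5-dimethoxyphenyl in place of 3-chlorophenyl gives a 1.2-fold lower number from compound 1 to compound 4 (0.08 log units; within the scatter), again no readable change. Nothing measured here offers a reason for these results.

The compounds shown leave open whether a different group on this phenyl ring, such as an amine or a carboxylic acid in place of the fluorine, would shift the number beyond the scatter.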